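The source may report more compounds than this note shows. Statements on the series, on what has been measured and on what is new or still open speak of the compounds shown alone.

In an ADME assay on L929 cells (Mus musculus) for cytotoxicity, read by resazurin assay, with a stated time of 72 h (a lower number here means a stronger inhibitor, a higher number a weaker inhibitor), compound 3 (`COc1cccc(C(=O)/C=C/c2ccc3c(c2)B(O)OC3)c1`) reads > 10 ug/mL as a limit of the assay, not a number. Compound 1 (`O=C(/C=C/c1ccc2c(c1)B(O)OC2)c1ccccn1`) reads > 10 ug/mL as a limit too. Compound 2 (`O=C(/C=C/c1ccc2c(c1)B(O)OC2)c1ccccc1O`) reads > 10 ug/mL as a limit too. The series therefore has one shared reference point (the limit of > 10 ug/mL in this assay, at which 3 of the 3 values shown sit) and no numerical value yet. Compound 4 (`O=C(/C=C/c1ccc2c(c1)B(O)OC2)c1cccc(O)c1`) differs from compound 3 as methoxy to hydroxy (hydrogen in place of methyl on an oxygen on an aromatic ring) on an aromatic ring. Among the measured compounds shown here, with the only measured step (a step that the two limits leave unreadable from compound 1 to compound 2) unreadable in size, no step beyond the scatter is expected in this assay and no direction either. The expected step (a step that the limit leaves unreadable from compound 3 to compound 4) is an estimate only. Compound 4 is estimated at 15 ug/mL with an expected range from 8 ug/mL to 30 ug/mL and a further limit reading is likely.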

Compound 4, half-maximal inhibitory concentration: 7.56 ug/mL
Compound 4: middle estimate off by 2.0-fold (0.30 log units), on the high side; the whole stated range lies above it.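

In this assay, among the compounds shown here, compound 4 is the only compound of the series that gives a number and not a limit: the limit of > 10 ug/mL in this assay, at which 3 of the 4 values shown sit. Methoxy to hydroxy gives an at least 1.3-fold lower number from compound 3 to compound 4 (0.12 log units; that floor lies within the scatter), 3-hydroxyphenyl in place of 2-hydroxyphenyl gives an at least 1.3-fold lower number from compound 2 to compound 4 (0.12 log units; that floor lies within the scatter), and 3-hydroxyphenyl in place of pyridin-2-yl gives an at least 1.3-fold lower number from compound 1 to compound 4 (0.12 log units; that floor lies within the scatter). Each floor stays within the scatter, so none of these steps is yet shown to be a real difference.

On these data alone, the true distance of compound 1, compound 2 and compound 3 from compound 4 remains open. Also open, as far as these compounds go, is what an amine or a carboxylic acid in place of the hydroxy group would read.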